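Fluoro in Place of Methoxy on the Fused Ring

A few compounds are considered here, and "the series" means these few. Any claim that something is new, unique, unknown or untested is made for them only; others in the source may bear on it.

Of the compounds shown here, three that share a common core have been tested in a functional assay on LNCaP cells (Homo sapiens) for cytotoxicity, read by MTT assay, with a stated time of 48 h, in the presence of a further agent that is not named here; a higher number here means a weaker inhibitor, a lower number a stronger inhibitor. Compound 1, `O=C(NCc1ccccc1)c1csc(-c2c[nH]c3ccccc23)n1`, reaches only the limit of the assay, giving > 100000 nM. Compound 2, `COc1ccc(NC(=O)c2csc(-c3cn(Cc4ccc(Cl)cc4)c4ccccc34)n2)cc1`, likewise reaches only the limit, with > 100000 nM. For the measured compounds named here, compound 3, `COc1ccc2[nH]cc(-c3nc(C(=O)Nc4cc(OC)c(OC)c(OC)c4)cs3)c2c1`, is the one compound with an actual number: in this assay compound 3 gives 84800 nM. Two of the three results sit at the limit of > 100000 nM in this assay, at which 2 of the 3 values shown sit.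

Compound 4, `COc1cc(NC(=O)c2csc(-c3c[nH]c4ccc(F)cc34)n2)cc(OC)c1OC`, has not yet been measured. It differs from compound 3 by fluoro in place of methoxy on an aromatic carbon. No measured pair with a change of this kind is available, so the size of such a change has no precedent among these compounds. The step is therefore expected to be small, likely within the scatter of repeated measurements, with no clear direction. Compound 4 is thus expected to give 90000 nM in this assay, within a range from 30000 nM to 200000 nM. The expected step is a 1.1-fold higher number from compound 3 to compound 4 (0.03 log units; within the scatter).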

Compound 4, half-maximal inhibitory concentration: 88500 nM
Compound 4: middle estimate off by 1.0-fold (0.01 log units), on the high side; measured number inside the range.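

Swapping methoxy for fluoro at this position gives, in this assay, a 1.0-fold higher number from compound 3 to compound 4 (0.02 log units; within the scatter), so the two compounds cannot be told apart here. This is the first pair shown that differs in one place, and it shows that the methoxy, with its one hydrogen-bond acceptor, can give way to fluoro on this aromatic carbon without a change beyond the scatter. Both numbers still lie close to the top of what this test can read, so the pair says little about how this position would behave in a stronger compound: the limit of > 100000 nM in this assay, at which 2 of the 4 values shown sit.

Going by these compounds, whether an amine, a carboxylic acid or a longer chain at this position would shift the number stays open. So does whether fluoro and methoxy would still read alike if the rest of the molecule were different.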